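This account rests on a few compounds, and the source may have more. Where it says the series, first, only, none or still open, it means among the compounds named here.

Working notes on the series, read in a functional assay on A-375 cells (Homo sapiens) for inhibition, read by CCK-8 assay, with a stated time of 72 h, tested at 8 uM; on this read-out higher numbers stand for more inhibition of growth at the one concentration tested and lower numbers for less inhibition of growth:

- compound 1 `Nc1ccccc1NC(=O)c1ccc(CSc2cccc(F)c2)cc1`: 76.3%
- compound 2 `Nc1ccccc1NC(=O)/C=C/c1ccc(CSc2ccc(F)cc2)cc1`: 24.6%
- compound 3 `COc1ccc(SCc2ccc(C(=O)Nc3ccccc3N)cc2)cc1OC`: 84.6%

Compound 1 lies within the scatter of compound 3, so those two cannot be separated on these numbers. Compound 2 lies beyond the scatter below compound 1. The next compound to be read is compound 4 `Nc1ccccc1NC(=O)c1ccc(CSc2ccc(F)cc2)cc1`, which has 4-fluorophenyl in place of 3-fluorophenyl on a sulfur. Going by the values given here, no measured pair isolates this change, so the expectation in this assay rests on the change itself, which keeps the same atoms, and no step beyond the scatter is expected. The expected size is a number 1.3 percentage points lower from compound 1 to compound 4 (within the scatter). The estimate for compound 4 is 75%, with an expected range of 60% to 87%.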

Compound 4, percent growth inhibition at one concentration: 54.3%
For compound 4 the middle estimate is 20.7 percentage points above the measured one, and the stated range ends above it.
By their numbers in this assay, from the lowest: compound 2; then compound 4; then compounds 1 and 3 (each within the scatter of the next).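

In this assay, 4-fluorophenyl in place of 3-fluorophenyl on a sulfur gives a number 22 percentage points lower from compound 1 to compound 4 (beyond the scatter). Going by these compounds alone, this position therefore responds to where the fluorine stands on the phenyl ring, even with the same atoms, which no earlier pair could show. The information at hand offers no explanation for this step.

From the compounds shown here alone, it remains open how plain phenyl or 2-fluorophenyl on the same sulfur would read. Also open, going by these compounds, is whether 3-chlorophenyl and 4-chlorophenyl would differ in the same direction as the two fluorophenyl groups.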